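The source may hold more compounds than are shown below. What is called first, only, known or untested is meant among the compounds shown, and "the series" means these compounds.

Measured in a functional assay on KYSE-510 cells (Homo sapiens) for antiproliferative activity, read by crystal violet staining, with a stated time of 96 h; a higher number here means a weaker inhibitor of growth, a lower number a stronger inhibitor of growth:
compound 1 `CC(=O)Nc1ccc(S(=O)(=O)NC2=NCCN2C(=S)SN2CCn3c2nsc3=S)cc1` gives >= 20000 nM
compound 2 `O=S(=O)(NC1=NCCN1C(=S)SN1CCn2c1nsc2=S)c1ccc(Cl)cc1` gives >= 20000 nM

The value of compound 1 in this assay is a limit, not a number. The value of compound 2 in this assay is likewise a limit, so compound 2 stands only at the floor of what was resolved. Among the measured compounds shown here, the one measured step, a step that the two limits leave unreadable from compound 1 to compound 2, cannot be read because of the limit of >= 20000 nM in this assay, at which 2 of the 2 values shown sit. Compound 3 `O=S(=O)(NC1=NCCN1C(=S)SN1CCn2c1nsc2=S)c1cccc2ccccc12` differs from compound 2 in one place: naphthalen-1-yl in place of 4-chlorophenyl on a sulfonyl sulfur. For the measured compounds named here, no measured step bears on this change, so no direction or size beyond the scatter can be drawn from the data. Compound 3 is therefore expected to sit near the same limit, estimated at 20000 nM, within 10000 nM to 40000 nM. The expected step of a number no higher from compound 2 to compound 3 (the limit leaves the size open) is accordingly small.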

Compound 3, concentration for 50% growth inhibition: >= 20000 nM
Compound 3 gave a limit, no number; the forecaster's own chance of this, stated with the estimate: 75%; the middle value lies on the limit itself.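

No step from compound 2 to compound 3 or from compound 1 to compound 3 can be read: the limit of >= 20000 nM in this assay, at which 3 of the 3 values shown sit.

The compounds shown leave open whether 4-acetamidophenyl, 4-chlorophenyl and naphthalen-1-yl on the sulfonyl sulfur differ at all in growth inhibition.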